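The source may report more compounds than this note shows. Statements on the series, on what has been measured and on what is new or still open speak of the compounds shown alone.

Measured in an ADME assay on microsomes from liver (Homo sapiens) for metabolic stability; a higher number here means faster removal of the compound, a lower number slower removal:
- Compound 1 `Cc1csc(C(=O)N[C@H]2CN(S(=O)(=O)c3ccccc3)C[C@@H]2C(=O)N[C@H]2CCCNC2)n1`: 9.1 mL.min-1.g-1
- Compound 2 `O=C(N[C@H]1CN(S(=O)(=O)c2ccccc2)C[C@@H]1C(=O)N[C@H]1CCCNC1)c1nnc(-c2ccc(F)cc2)s1`: 8.8 mL.min-1.g-1
- Compound 3 `O=C(N[C@H]1CN(S(=O)(=O)c2ccccc2)C[C@@H]1C(=O)N[C@H]1CCCNC1)c1cc(-c2ccccc2Cl)on1`: < 3 mL.min-1.g-1

Compound 3 stands at the limit of < 3 mL.min-1.g-1 in this assay, at which 1 of the 3 values shown sits. Its reading of < 3 mL.min-1.g-1 is a limit and not a number.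

All three measured steps change the group on the carbonyl carbon. The first, a 1.0-fold lower number from compound 1 to compound 2 (0.01 log units; within the scatter), stays within the scatter, whereas an at least 3.0-fold lower number from compound 1 to compound 3 (0.48 log units; beyond the scatter) and an at least 2.9-fold lower number from compound 2 to compound 3 (0.46 log units; beyond the scatter) both go beyond it. Compound 4 `O=CN1CCC[C@H](NC(=O)[C@H]2CN(S(=O)(=O)c3ccccc3)C[C@@H]2NC(=O)c2cc(-c3ccccc3Cl)on2)C1` keeps that group from compound 3 and changes another place instead: formyl in place of hydrogen on an amine nitrogen in a ring, with formyl in place of hydrogen on an amine nitrogen in a ring. Among the compounds with values here, no measured step touches that nitrogen, so the steps offer only a rough guide to size, not a direct precedent.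

Since compound 3 sits at a limit, any further fall in this assay could not be read as a number. A modest rise is therefore the expectation, of about the size seen in an at least 2.9-fold lower number from compound 2 to compound 3 (0.46 log units; beyond the scatter), though in the opposite direction and with real uncertainty. The expected move is an at least 1.6-fold higher number from compound 3 to compound 4 (0.22 log units; that floor lies within the scatter). For compound 4 the estimated value is 5 mL.min-1.g-1, with an expected range of 3 mL.min-1.g-1 to 14 mL.min-1.g-1.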

Compound 4, intrinsic clearance in microsomes: > 259 mL.min-1.g-1
Compound 4: a limit, no number (the forecaster's own chance of this, stated with the estimate: 35%); middle value at least 51-fold (1.71 log units) from the limit.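

In this assay, formyl in place of hydrogen on an amine nitrogen in a ring gives an at least 86-fold higher number from compound 3 to compound 4 (1.93 log units; beyond the scatter), a large step at a place that none of the earlier measured steps touched. Compound 4 reads > 259 mL.min-1.g-1, which is a limit and not a number, and the reading of compound 3 is a limit too, so the step gives only a floor for the size of the change. The earlier steps shown here all changed the group on the carbonyl carbon, whereas compound 3 and compound 4 share that group, so this pair shows that the amine nitrogen in the six-membered ring is itself a place where this read-out can shift strongly, with only formyl entering.

Nothing shown here gives a measured property that could account for this rise. Still open, as far as these compounds go, is whether a different group on that nitrogen, such as acetyl or methyl, would give a step of similar size, and whether formyl there would do the same alongside the groups on the carbonyl carbon of compound 1 and compound 2.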